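Swapping a cyclopentylmethyl group for a dichlorophenyl ring

This account rests on a few compounds, and the source may have more. Where it says the series, first, only, none or still open, it means among the compounds named here.

Compounds measured so far:
compound 1, `C[C@H](NC(=O)C(=O)NCCC1CCCC1)C(=O)N[C@@H](CC(=O)O)C(=O)COc1c(F)c(F)cc(F)c1F`: 11 nM
compound 2, `C[C@H](NC(=O)C(=O)NCc1ccccc1F)C(=O)N[C@@H](CC(=O)O)C(=O)COc1c(F)c(F)cc(F)c1F`: 207 nM

Both compounds share a common core and differ only in the group on a saturated chain carbon bound to an amide-type nitrogen. In a functional assay on Jurkat cells (Homo sapiens) (on this read-out lower numbers stand for stronger inhibition and higher numbers for weaker inhibition), compound 1 gives 11 nM, the lowest of the two numbers, so it is the stronger inhibitor of the pair. For the measured compounds named here, compound 2 gives 207 nM, and the single measured step, a 19-fold higher number from compound 1 to compound 2 (1.27 log units; beyond the scatter), shows that replacing the cyclopentylmethyl group with an aromatic ring costs a great deal of potency.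

Compound 3, `C[C@H](NC(=O)C(=O)NCc1cc(Cl)ccc1Cl)C(=O)N[C@@H](CC(=O)O)C(=O)COc1c(F)c(F)cc(F)c1F`, has not yet been measured. It differs from compound 1 as follows: 2,5-dichlorophenyl in place of cyclopentylmethyl on a saturated chain carbon bound to an amide-type nitrogen. As in compound 2, a saturated five-membered ring is replaced by a six-membered aromatic one, here carrying two chlorines rather than one fluorine. Going by the values given here, the one step that bears on this change is a 19-fold higher number from compound 1 to compound 2 (1.27 log units; beyond the scatter), and a step of similar kind and size is therefore expected here. For compound 3 the number is expected to be 150 nM (range 40 nM to 600 nM), a loss described by the expected step of a 14-fold higher number from compound 1 to compound 3 (1.13 log units; beyond the scatter).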

Compound 3, half-maximal inhibitory concentration: 4.3 nM
Beside the measured number, compound 3's estimate is 35-fold (1.54 log units) above it; measured number below the stated range.
By their numbers in this assay, from the lowest: compound 3; then compound 1; then compound 2.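

In this assay, the 2,5-dichlorophenyl group gives a 2.6-fold lower number from compound 1 to compound 3 (0.41 log units; beyond the scatter), so an aromatic ring on this saturated chain carbon bound to an amide-type nitrogen does not necessarily cost potency, as compound 2 alone might have suggested. Keeping an aromatic ring and changing only what it carries gives a 48-fold lower number from compound 2 to compound 3 (1.68 log units; beyond the scatter), and this large step shows that the 2-fluorophenyl and 2,5-dichlorophenyl groups are far from interchangeable here, with compound 3 the strongest inhibitor of the three. No measurement is available to explain why the dichlorinated ring outperforms both the fluorinated ring and the cyclopentylmethyl group.

Because compound 3 differs from compound 2 by both the loss of a fluorine and the gain of two chlorines, these compounds cannot show how much each chlorine contributes or whether chlorine itself is essential. A plain phenyl ring, a phenyl ring with a single chlorine, and a phenyl ring with two methyl groups in place of the chlorines would each help separate these possibilities.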